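The source may report more compounds than this note shows. Statements on the series, on what has been measured and on what is new or still open speak of the compounds shown alone.

Measured compounds in an assay on FRT-Jurkat cells for inhibition of nuclear factor NF-kappa-B complex (Homo sapiens), read by flow cytometry, with a stated time of 24 h, tested at 10 uM; on this read-out higher numbers stand for more inhibition at the one concentration tested (going by the name of the read-out) and lower numbers for less inhibition:
compound 1 `CCCCCc1ccc(Nc2ccc3c(c2)C(=O)N(C2CCC(=O)NC2=O)C3=O)cc1` — 12%
compound 2 `CCCc1ccc(Nc2ccc3c(c2)C(=O)N(C2CCC(=O)NC2=O)C3=O)cc1` — 10%

Both measured compounds share the core of compound 1 and differ only in the chain on the aryl ring. Among the measured compounds shown here, compound 2 stands at 10%, and its only neighbour on these numbers, compound 1, stands at 12%, so the two lie within the scatter of each other; the single measured step, a number 2 percentage points lower from compound 1 to compound 2 (within the scatter), confirms that shortening the chain changed nothing that can be told from the data.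

Compound 3 `Cc1ccccc1Nc1ccc2c(c1)C(=O)N(C1CCC(=O)NC1=O)C2=O` is not yet measured. Relative to compound 2 the change is 2-methylphenyl in place of 4-propylphenyl on a nitrogen on an aromatic ring. For the measured compounds named here, no measured step touches a change of this kind, since the only step on record alters chain length and not the pattern on the aryl ring, and that step was within the scatter. With nothing to suggest movement in either direction, the account expects compound 3 to remain near the measured pair, with a step of a number 2 percentage points higher from compound 2 to compound 3 (within the scatter) that is expected to lie within the scatter. Compound 3 is therefore estimated at 12%, in a range from 0% to 30%.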

Compound 3, a percentage reported as inhibition, at one concentration (the size of the read-out at that concentration, not a potency): 2%
Compound 3: the middle estimate sits 10 percentage points above what was measured; the range from low to high includes it.
By their numbers in this assay, from the lowest: compounds 3, 2 and 1 (each within the scatter of the next).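

Replacing the whole group at this place, with 2-methylphenyl in place of 4-propylphenyl on the nitrogen on an aromatic ring, gives a number 8 percentage points lower from compound 2 to compound 3 (within the scatter) in this assay. Unlike the earlier step, which altered only chain length, this exchange alters the aryl group itself, yet it too stays inside the scatter, so the numbers give no ranking of these two groups at this place. Nothing measured here offers an explanation for this result.

The compounds shown leave open whether an amine or a carboxylic acid on the aryl ring, or a chain longer than those shown, would give a number beyond the scatter of these three. They also leave open whether 4-methylphenyl would read differently from 2-methylphenyl in this assay.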